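Aryl-to-piperidinyl swap on the oxadiazole series

The source may report more compounds than this note shows. Statements on the series, on what has been measured and on what is new or still open speak of the compounds shown alone.

Working notes on a small set tested in a functional assay on LNCaP cells (Homo sapiens) for antiproliferative activity, read by MTT assay, with a stated time of 24 h; a lower number here means a stronger inhibitor, a higher number a weaker inhibitor. Compound 1 `COc1ccc(-c2noc(-c3ccccc3)n2)cc1OC1CCCC1` gives only a limit, > 1000000 nM, in this assay. Compound 2 `COc1cc(-c2noc(-c3ccncc3)n2)ccc1OCc1ccccc1` likewise returns a limit, > 1000000 nM, in this assay. Within the data shown here, compound 3 `COc1ccc(-c2noc(-c3ccc(Cl)cc3)n2)cc1OC1CCCC1` is the one member with a measured number, 20800 nM in this assay, so it stands as the sole anchor; the other two sit at the limit of > 1000000 nM in this assay, at which 2 of the 3 values shown sit. Among the measured compounds shown here, the only measured step, an at least 48-fold lower number from compound 1 to compound 3 (1.68 log units; beyond the scatter), shows that a chloro on the aromatic ring carries the whole observed gain.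

Compound 4 `COc1ccc(-c2noc(C3CCNCC3)n2)cc1OC1CCCC1` differs from compound 3 by piperidin-4-yl in place of 4-chlorophenyl on an aromatic carbon. For the measured compounds named here, no measured step bears directly on this exchange; what is known is that the chloro-bearing aryl is what separates compound 3 from the limit values. Removing that group altogether is therefore expected to cost potency in this assay, with a 19-fold higher number from compound 3 to compound 4 (1.28 log units; beyond the scatter) as the estimated step, and it is plausible that the outcome would be a limit rather than a number. For compound 4 the estimate in this assay is 400000 nM, ranging from 60000 nM to 3000000 nM.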

Compound 4, half-maximal inhibitory concentration: 10 nM
The estimate for compound 4 lay 40000-fold (4.60 log units) above the measured number, outside the stated range (below it).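

At this position, on an aromatic carbon of a five-membered aromatic ring with 2 nitrogen and 1 oxygen, an aryl group is not required for a low number in this assay, and the chloro-bearing aryl is not the best group in the set: the exchange for piperidin-4-yl gives a 2100-fold lower number from compound 3 to compound 4 (3.32 log units; beyond the scatter). Against the plain phenyl, the same exchange gives an at least 100000-fold lower number from compound 1 to compound 4 (5.00 log units; beyond the scatter), a step that starts from a limit and not from a number. Compound 1 and compound 2 remain limits: the limit of > 1000000 nM in this assay, at which 2 of the 4 values shown sit.

The compounds shown leave open whether the ring nitrogen or the non-aromatic ring accounts for the step, which a cyclohexyl or an open-chain amine at this position would separate. Also open, on these data alone, is whether a methyl or acetyl on the piperidine nitrogen is tolerated.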